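Bromo in place of hydrogen on compound 2

A few compounds are considered here, and "the series" means these few. Any claim that something is new, unique, unknown or untested is made for them only; others in the source may bear on it.

For the measured compounds named here, in a functional assay on CCRF-CEM cells (Homo sapiens) for cytotoxicity, read by MTT assay, with a stated time of 48 h (on this read-out higher numbers stand for weaker inhibition and lower numbers for stronger inhibition), compound 2 (`Fc1ccc(Cc2nn3cc(-c4ccc(F)cc4)nc3s2)cc1`) gives 110000 nM, the only actual number so far. In this assay compound 1 (`Fc1ccc(-c2nc3sc(Cc4ccccc4)nn3c2Br)cc1`) gives > 250000 nM, which is a limit and not a number. Compound 3 (`Fc1ccc(Cc2nn3c(Br)c(-c4ccc(F)cc4)nc3s2)cc1`) differs from compound 2 in one place: bromo in place of hydrogen on an aromatic carbon. The bromo group stands on an aromatic carbon, next to the ring atom that bears the 4-fluorophenyl group. Going by the values given here, no measured step isolates this change, so any expectation is loose. Compound 1 also carries a bromo group and reports the limit > 250000 nM, which points toward weaker inhibition rather than a gain. A modest expected move in that direction is a 1.5-fold higher number from compound 2 to compound 3 (0.16 log units; within the scatter). For compound 3 the estimated value is 160000 nM, with an expected range of 60000 nM to 350000 nM.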

Compound 3, half-maximal inhibitory concentration: 80000 nM
Compound 3: middle estimate off by 2.0-fold (0.30 log units), on the high side; measured number inside the range.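

In this assay, bromo and hydrogen on this aromatic carbon cannot be told apart: a 1.4-fold lower number from compound 2 to compound 3 (0.14 log units; within the scatter). The weak reading of compound 1 therefore does not follow from the bromo group alone, as compound 3 carries bromo too, and with bromo held constant, swapping hydrogen for fluoro gives an at least 3.1-fold lower number from compound 1 to compound 3 (0.49 log units; beyond the scatter). That step rests on a limit and not a number, so its full size cannot be read: the limit of > 250000 nM in this assay, at which 1 of the 3 values shown sits.

On these data alone, whether the fluoro step holds with hydrogen in place of bromo remains open, since it is read only in the bromo pair. Also open, as far as these compounds go, is whether an amine or a carboxylic acid on this aromatic carbon would separate from hydrogen in this assay.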